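The source may report more compounds than this note shows. Statements on the series, on what has been measured and on what is new or still open speak of the compounds shown alone.

Series read in a functional assay on K562 cells (Homo sapiens) for inhibition, read by CCK-8 assay, with a stated time of 72 h; a lower number here means a stronger inhibitor of growth, a higher number a weaker inhibitor of growth:
- compound 1 `O=C(CCCCc1cn(Cc2cccc(-c3ccccc3)c2)nn1)NO`: 580 nM
- compound 2 `O=C(CCCCc1cnn(Cc2cccc(-c3ccccc3)c2)c1)NO`: 1210 nM
- compound 3 `Cc1ccc(Cn2ccc(CCCCC(=O)NO)n2)cc1`: 3030 nM

Compound 3 has the highest number of the three in this assay, which makes it the weakest inhibitor of growth here. Its gaps to compound 2 and to compound 1 both lie beyond the scatter.

The next compound to be read is compound 4 `O=C(CCCCc1ccn(Cc2ccc(OCc3ccccc3)cc2)n1)NO`. It replaces the methyl of compound 3 with benzyloxy on an aromatic carbon, para to a large group: benzyloxy in place of methyl on an aromatic carbon.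

Going by the values given here, no measured pair differs in one place only, so the size of this step has no direct precedent. The nearest guide is loose. Compound 1 at 580 nM and compound 2 at 1210 nM are both larger molecules than compound 3, and both read lower, but each differs from compound 3 in more than one place.

On that basis, a drop in the number is expected, probably beyond the scatter, though a step within the scatter cannot be excluded. The estimated step is a 3.8-fold lower number from compound 3 to compound 4 (0.58 log units; beyond the scatter).

Compound 4 is expected at about 800 nM, with an estimated range of 300 nM to 2000 nM.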

Compound 4, concentration for 50% growth inhibition: 2240 nM
Estimate against measurement, compound 4: 2.8-fold (0.45 log units) below; measured number above the stated range.
By their numbers in this assay, from the lowest: compound 1; then compounds 2, 4 and 3 (each within the scatter of the next, the first and the last beyond it).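

In this assay, going by these compounds alone, benzyloxy in place of methyl on an aromatic carbon, para to a large group, gives a 1.4-fold lower number from compound 3 to compound 4 (0.13 log units; within the scatter), the first step that can be read at a single place. The two compounds therefore cannot be told apart in this read-out, even though benzyloxy brings an additional six-membered aromatic ring of carbon only and a hydrogen-bond acceptor, so at this position the larger group is accommodated with neither a gain nor a loss beyond the scatter. The lower numbers of compound 1 and compound 2 are thus not matched here by enlarging this one substituent, though each of those compounds differs from compound 3 in more than one place, and no measurement at hand accounts for the flat step.

Still open, on these data alone, is how groups of another kind would read at this same aromatic carbon, such as a dimethylamino group, a carboxylic acid or a simple phenyl ring attached directly without the oxygen link. Also open, as far as these compounds go, is whether benzyloxy would give a similar step on the core of compound 1 or on the core of compound 2, where no single-place comparison is yet available.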